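Cytotoxicity notes on compounds 1 to 4

The compounds below may be only part of what the source reports. "The series", "measured", "known", "first", "only" and "open" are said of these compounds alone.

Compound 1 `COc1ccc(CCC2(C3CCCC3)CC(O)=C(Cc3nc4nc(C)cc(C)n4n3)C(=O)O2)cc1F`, compound 2 `COc1ccc(CCC2(C3CCCC3)CC(O)=C(Cc3nc4nc(C)cc(C)n4n3)C(=O)O2)cc1C` and compound 3 `CCOc1ccc(CCC2(C3CCCC3)CC(O)=C(Cc3nc4nc(C)cc(C)n4n3)C(=O)O2)cc1Cl` share one core and differ only in the substituents of the aromatic ring named in the steps below. In an ADME assay on Huh-7 cells (Homo sapiens) for cytotoxicity (a lower number here means that less compound is tolerated, a higher number that more compound is tolerated), compound 1 reaches only the limit of > 32000 nM. In this assay compound 2 likewise stops at the limit of > 32000 nM. In this assay compound 3 also gives the limit of > 32000 nM. Compound 3 thus stands at the ceiling of what the assay reports, together with the other two, as shown by the limit of > 32000 nM in this assay, at which 3 of the 3 values shown sit. The steps a step that the two limits leave unreadable from compound 1 to compound 2, a step that the two limits leave unreadable from compound 1 to compound 3 and a step that the two limits leave unreadable from compound 2 to compound 3 are consequently of unknown size; the limit hides them.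

Compound 4 `Cc1cc(C)n2nc(CC3=C(O)CC(CCc4ccc(S(C)(=O)=O)c(Cl)c4)(C4CCCC4)OC3=O)nc2n1` is not yet measured. It differs from compound 3 in that (methylsulfonyl in place of ethoxy on an aromatic carbon). For the measured compounds named here, no measured step bears readably on this change, since every value in the set sits at the limit and no step size is available. The expected step is a number no higher from compound 3 to compound 4 (the limit leaves the size open), meaning none beyond the scatter, with the limit most likely reached again. Compound 4 is therefore estimated at 32000 nM, within a range of 16000 nM to 64000 nM.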

Compound 4, half-maximal cytotoxic concentration: > 32000 nM
Compound 4 was reported as a limit (the forecaster's own chance of this, stated with the estimate: 85%); the middle value lies on the limit itself.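

In this assay compound 4 also stops at a limit, > 32000 nM, so its steps from compound 1, compound 2 and compound 3 cannot be read, as all values sit at the ceiling: the limit of > 32000 nM in this assay, at which 4 of the 4 values shown sit.

The compounds shown leave open whether any of these aromatic ring changes shifts the half-maximal cytotoxic concentration at all.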